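The compounds below may be only part of what the source reports. "The series", "measured", "known", "first", "only" and "open" are said of these compounds alone.

In a functional assay on A549 cells (Homo sapiens) for cytotoxicity, read by XTT assay, with a stated time of 72 h (a higher number here means a weaker inhibitor, a lower number a stronger inhibitor), compound 1 (`CCCCCCCC/C=C\CCCCCCCCOc1cc(O)cc(O)c1C(C)=O`) gives > 100000 nM as its result, which is a limit of the assay and not a number. Compound 2 (`CC(=O)c1c(O)cc2c(c1O)CCC(C)(C)O2`) gives > 100000 nM in this assay as its result, again a limit. Among the measured compounds shown here, compound 3 (`CC(C)=CCC/C=C(\C)Cc1c(O)cc(O)c2c(=O)c(OC/C=C(\C)CCC=C(C)C)c(-c3ccc(O)cc3)oc12`) reads 26000 nM in this assay and stands alone as the only compound here with an actual number.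

Compound 4 (`CC(C)=CCC/C(C)=C/COc1c(-c2ccc(O)cc2)oc2cc(O)cc(O)c2c1=O`) differs from compound 3 in one place: hydrogen in place of 2,7-dimethylocta-2,6-dien-1-yl on an aromatic carbon. Put simply, hydrogen replaces 2,7-dimethylocta-2,6-dien-1-yl on an aromatic carbon, and the rest of the structure stays the same.

For the measured compounds named here, no two measured compounds here differ in only one place, so no direct precedent shows how large this step should be. The expectation therefore starts from compound 3 at 26000 nM and remains uncertain. A moderate move to a higher number in this assay is expected, which would mean a weaker inhibitor, although a change no larger than the usual scatter remains possible. The expected change is a 2.3-fold higher number from compound 3 to compound 4 (0.36 log units; beyond the scatter) in size. Compound 4 is estimated at 60000 nM in this assay, with an expected range of 25000 nM to 100000 nM for its measurement.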

Compound 4, half-maximal inhibitory concentration: 27000 nM
The estimate for compound 4 lay 2.2-fold (0.35 log units) above the measured number, and the stated range covers the measured number.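

Among the compounds shown here, the step of a 1.0-fold higher number from compound 3 to compound 4 (0.02 log units; within the scatter) in this assay gives the first direct view of a single structural change in this set, since no earlier pair differed in only one place. It shows that 2,7-dimethylocta-2,6-dien-1-yl can be replaced by hydrogen on this aromatic carbon without a difference that the assay can separate from ordinary scatter. For this pair, then, the presence of that large chain at this position is not needed for the cytotoxicity read here, although a single pair cannot establish a wider rule.

The compounds shown leave open whether a different group on this aromatic carbon, such as an amine, a carboxylic acid or a shorter chain, would behave in the same way, and whether the other chain shared by compound 3 and compound 4 matters for the reading. Compound 1 and compound 2 add no number to compare with, only a limit of the assay: the limit of > 100000 nM in this assay, at which 2 of the 4 values shown sit.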